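The source may hold more compounds than are shown below. What is called first, only, known or untested is meant among the compounds shown, and "the series" means these compounds.

Measured in a functional assay on HT-29 cells (Homo sapiens) for cytotoxicity, read by MTT assay, with a stated time of 24 h, tested at 32 ug/mL; on this read-out lower numbers stand for a weaker effect and higher numbers for a stronger effect at the one concentration tested:

Compound 1, `Cn1c(-c2ccc(NC(=O)CSc3nc4ccccc4s3)cc2)nc(-c2ccccc2)c1-c1ccccc1`, gives 66%.
Compound 2, `Cc1nnc(SCC(=O)Nc2ccc(-c3nc(-c4ccccc4)c(-c4ccccc4)n3C)cc2)s1`, gives 87.1%.
Compound 3, `Cn1c(-c2ccc(NC(=O)CN3CCN(c4ccccc4)CC3)cc2)nc(-c2ccccc2)c1-c1ccccc1`, gives 60.5%.

On these three numbers compound 3 stands lowest. Its nearest neighbour is compound 1, the step being a number 5.5 percentage points lower from compound 1 to compound 3 (within the scatter), so the two cannot be told apart. The furthest is compound 2, with a number 26.6 percentage points lower from compound 2 to compound 3 (beyond the scatter), a real gap. Within the data shown here, the one step that lies beyond the scatter among the measured compounds, a number 21.1 percentage points higher from compound 1 to compound 2 (beyond the scatter), exchanges one ring on the sulfur for another.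

Compound 4, `Cn1c(-c2ccc(NC(=O)CN3CCN(Cc4ccc(Cl)cc4)CC3)cc2)nc(-c2ccccc2)c1-c1ccccc1`, differs from compound 3 in a single place: 4-chlorobenzyl in place of phenyl on an amine nitrogen in a ring. Among the measured compounds shown here, none of the measured steps touches this place. The steps into compound 3 from compound 1 and from compound 2 exchange the whole group on the chain carbon bound to the carbonyl, and the step from compound 1 to compound 2 exchanges a ring on a sulfur; the group on the amine nitrogen of the six-membered ring has so far been phenyl in compound 3 alone. For the measured compounds named here, there is therefore no measured step to lean on, and the expected step for compound 4 is one that stays within the scatter, in no particular direction, estimated as a number 1.5 percentage points higher from compound 3 to compound 4 (within the scatter). The estimate for compound 4 in this assay is 62%, between 44% and 80%.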

Compound 4, a percentage reported as activity, at one concentration (the size of the read-out at that concentration, not a potency): 55.6%
Compound 4: the middle estimate sits 6.4 percentage points above what was measured; the measured number falls inside the stated range.
By their numbers in this assay, from the lowest: compounds 4, 3 and 1 (each within the scatter of the next, the first and the last beyond it); then compound 2.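

In this assay, replacing phenyl with 4-chlorobenzyl on the amine nitrogen in the ring gives a number 4.9 percentage points lower from compound 3 to compound 4 (within the scatter), so compound 3 and compound 4 cannot be told apart. Among these compounds, this is the first measured change at this position, and it shows that a group of 8 heavy atoms, one of them chlorine, in place of one of 6 leaves no difference that can be separated from the usual scatter of this read-out. No measurement at hand speaks to why the two compounds read alike.

Because the ring gains a chlorine and the group gains a carbon in the same step, the compounds shown cannot separate these two parts of the change, which benzyl or 4-chlorophenyl on the same nitrogen could begin to do. Also open, going by these compounds, is whether a much smaller group such as methyl, or a group that carries an amine or a carboxylic acid, would give a number clearly apart from that of compound 3.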